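Working notes: two measured compounds and one to come

This account rests on a few compounds, and the source may have more. Where it says the series, first, only, none or still open, it means among the compounds named here.

Measured so far:
Compound 1 `C=C(C)C(=O)c1ccc(OC)cc1OC` — in a functional assay on the whole organism (strain albino) for inhibition, with Rattus norvegicus as the target, read by paw edema, with stated times of 30 min and 3 h, at a dose of 25 mg/kg by the intraperitoneal route (a higher number here means more inhibition at the dose given (going by the name of the read-out), a lower number less inhibition), compound 1 gives 31.5%.
Compound 2 `CCOC(=O)c1nn(-c2ccccc2)c(-c2ccc(OC)cc2OC)c1-c1ccccc1` — in this assay compound 2 gives 20.8%.

Compound 2 stands lowest of the two numbers available; the nearest, compound 1, lies higher by a gap beyond the usual scatter. Among the measured compounds shown here, no pair of measured compounds differs in one place, so no measured step is at hand.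

Compound 3 `CCOC(=O)c1nn(-c2ccccc2)c(-c2ccc(OC)cc2OC)c1C` differs from compound 2 in one place: methyl in place of phenyl on an aromatic carbon. The core is kept, as are the ethoxycarbonyl, the 2,4-dimethoxyphenyl and the phenyl on the ring nitrogen.

For the measured compounds named here, with no measured step of this kind, the expected step from compound 2 to compound 3 in this assay is none beyond the scatter, that is a number 1.2 percentage points higher from compound 2 to compound 3 (within the scatter). Compound 3 is therefore estimated at 22% in this assay, with a range from 8% to 36%.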

Compound 3, a percentage reported as inhibition, in the whole organism at one dose (the size of the read-out at that dose, not a potency): 5.81%
Compound 3: the middle estimate sits 16.2 percentage points above what was measured, and the stated range ends above it.
By their numbers in this assay, from the lowest: compound 3; then compound 2; then compound 1.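

In this assay, the aromatic carbon on the five-membered aromatic ring is sensitive to its substituent: methyl in place of phenyl there gives a number 15 percentage points lower from compound 2 to compound 3 (beyond the scatter). Among the compounds shown here, this is the only measured step at this position, and it shows that inhibition at the dose given changes with this group alone, while the ethoxycarbonyl, the 2,4-dimethoxyphenyl and the phenyl on the ring nitrogen stay the same. No measurement at hand gives a reason for this step.

Going by these compounds, with only phenyl and methyl at this carbon, it remains open whether a longer chain such as propyl, or an amine, would fall nearer to compound 2 or to compound 3. On these data alone, it is also open whether the step would hold with a carboxylic acid in place of the ethoxycarbonyl.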